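The compounds below may be only part of what the source reports. "The series", "measured", "known", "first", "only" and "open" are said of these compounds alone.

Measured so far in an in vitro functional assay on cells for agonist activity at Bombesin receptor subtype-3 (Mus musculus), read by luminescence and calcium flux; on this read-out lower numbers stand for an effect already at smaller amounts and higher numbers for an effect only at larger amounts of compound: compound 1 `O=C(O)c1ccccc1-c1ccc(CCc2ncc(CC3CCC3)[nH]2)cc1` gives 7.1 nM; compound 2 `CC(C)(C)Cc1cnc(CCc2ccc(-c3ccccc3C(=O)O)cc2)[nH]1` gives 6.3 nM; compound 3 `O=C(O)c1ccccc1-c1ccc(CCc2ncc(CCC3CCCCC3)[nH]2)cc1` gives 33 nM.

Compound 3 holds the highest number of the three: the step of a 4.6-fold higher number from compound 1 to compound 3 (0.67 log units; beyond the scatter) and the step of a 5.2-fold higher number from compound 2 to compound 3 (0.72 log units; beyond the scatter) both lie beyond the scatter, whereas a 1.1-fold lower number from compound 1 to compound 2 (0.05 log units; within the scatter) does not. Compound 4 `O=C(O)c1ccccc1-c1ccc(CCc2ncc(CC3CC3)[nH]2)cc1` differs from compound 3 by cyclopropyl in place of cyclohexylmethyl on a saturated chain carbon bound to an aromatic carbon. Compounds 1 and 2, with cyclobutyl and tert-butyl at the same place, sat together in this assay, and each of their steps to compound 3 was a modest loss. Among the measured compounds shown here, a step of roughly that size back in the opposite direction is therefore expected, a 3.3-fold lower number from compound 3 to compound 4 (0.52 log units; beyond the scatter), though no measured compound shows whether cyclopropyl reaches the level of compound 1. Compound 4 is estimated at 10 nM, range 4 nM to 30 nM.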

Compound 4, half-maximal effective concentration: 72 nM
Compound 4: middle estimate off by 7.2-fold (0.86 log units), on the low side; measured number above the stated range.
By their numbers in this assay, from the lowest: compounds 2 and 1 (each within the scatter of the next); then compound 3; then compound 4.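

In this assay, cyclopropyl on a saturated chain carbon bound to an aromatic carbon does not undo the loss seen with cyclohexylmethyl: the change gives a 2.2-fold higher number from compound 3 to compound 4 (0.34 log units; beyond the scatter) and moves further the same way. Against the two low-number compounds, the steps are a 10-fold higher number from compound 1 to compound 4 (1.01 log units; beyond the scatter) and an 11-fold higher number from compound 2 to compound 4 (1.06 log units; beyond the scatter), both large. Among these four compounds, the groups with the fewest and the most heavy atoms therefore both give higher numbers than cyclobutyl and tert-butyl.

On these data alone, whether cyclopentyl or an amine at this place keeps the low numbers remains open. No supporting measurement explains why cyclopropyl falls so far behind cyclobutyl.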